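Methoxy in place of chloro: notes on growth inhibition

The compounds below may be only part of what the source reports. "The series", "measured", "known", "first", "only" and "open" are said of these compounds alone.

Values so far in a functional assay on NCI-H460 cells (Homo sapiens) (a lower number here means a stronger inhibitor of growth, a higher number a weaker inhibitor of growth), for this series
Compound 1 `Cc1cc(C)c2c(O)cc(-c3ccc(Cl)cc3)nc2n1` gives 22400 nM
Compound 2 `Cc1ccnc2nc(-c3ccc(F)cc3)cc(O)c12` gives 32400 nM

Compound 1 stands level with compound 2, as the two values lie within the scatter of each other. Compound 3 `COc1ccc(-c2cc(O)c3c(C)cc(C)nc3n2)cc1` is not yet measured. It differs from compound 1 by methoxy in place of chloro on an aromatic carbon, para to a large group (methoxy in place of chloro on an aromatic carbon) and the rest of the structure is unchanged. For the measured compounds named here, no two measured compounds differ in one place only, so the data give no direct reading of this change. With compound 1 at 22400 nM and compound 2 at 32400 nM as the only anchors, no step beyond the scatter is expected in this assay in either direction. The expected change is a 1.1-fold higher number from compound 1 to compound 3 (0.05 log units; within the scatter) on this estimate. For compound 3 the estimated value is 25000 nM with an expected range from 10000 nM to 60000 nM in repeated measurements.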

Compound 3, concentration for 50% growth inhibition: 40700 nM
Compound 3: the middle estimate sits 1.6-fold (0.21 log units) below what was measured; measured number inside the range.
By their numbers in this assay, from the lowest: compounds 1, 2 and 3 (each within the scatter of the next).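

In this assay, for the compounds shown here, methoxy in place of chloro on an aromatic carbon, para to a large group, gives a 1.8-fold higher number from compound 1 to compound 3 (0.26 log units; within the scatter) and provides the first direct reading of a single change. At this position, on the core of compound 1, chloro and methoxy cannot be told apart in this assay, even though methoxy brings a hydrogen-bond acceptor that chloro lacks. No supporting measurement bears on this result.

The compounds shown leave open whether an amine, a carboxylic acid or a longer chain such as butoxy at the same position would give a step beyond the scatter. They also leave open whether methoxy in place of chloro reads the same way on a different core, as this single pair shows the change on one core only.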